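The source may report more compounds than this note shows. Statements on the series, on what has been measured and on what is new or still open speak of the compounds shown alone.

Of the compounds shown here, two carrying the same core have been tested in a functional assay on A549 cells (Homo sapiens) for cytotoxicity, read by MTT assay, with a stated time of 24 h, tested at 40 uM; on this read-out higher numbers stand for a weaker effect at the one concentration tested and lower numbers for a stronger effect. Compound 1 `CCCCCCCCCCCCCCOC(=O)CCC(=O)N1CCN(CCCOc2cc3c(Nc4ccc(F)c(Cl)c4)ncnc3cc2OC)CC1` gives 88.6%, and compound 2 `CCCCCCCCCCCCCCCCCOC(=O)CCC(=O)N1CCN(CCCOc2cc3c(Nc4ccc(F)c(Cl)c4)ncnc3cc2OC)CC1` gives 85.2%. Among the measured compounds shown here, compound 2 therefore stands alongside compound 1, the only other compound measured, with the two numbers within the usual scatter of each other: the step of a number 3.4 percentage points lower from compound 1 to compound 2 (within the scatter) tells how little that added chain length mattered to the read-out.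

Compound 3 `CCCCCCCCCCCCCCCCCCOC(=O)CCC(=O)N1CCN(CCCOc2cc3c(Nc4ccc(F)c(Cl)c4)ncnc3cc2OC)CC1` has not yet been measured. Its difference from compound 2 is methyl in place of hydrogen on a saturated chain carbon, ten or more bonds along the chain from an oxygen next to a carbonyl group. For the measured compounds named here, the only measured step that speaks to such a change is the one from compound 1 to compound 2, where a longer chain at the same place left the read-out within the scatter. On that basis the change to compound 3 is expected to move the number neither up nor down beyond the scatter, and the estimated step of a number 0.2 percentage points lower from compound 2 to compound 3 (within the scatter) reflects that expectation. Compound 3 is therefore estimated at 85% in this assay, with a range from 74% to 96%.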

Compound 3, a percentage reported as activity, at one concentration (the size of the read-out at that concentration, not a potency): 91%
The estimate for compound 3 lay 6 percentage points below the measured number, within the range that was stated.
By their numbers in this assay, from the lowest: compounds 2, 1 and 3 (each within the scatter of the next).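

On a saturated chain carbon, methyl in place of hydrogen gives a number 5.8 percentage points higher from compound 2 to compound 3 (within the scatter) in this assay. Butyl in place of hydrogen at the same place, the largest change among these compounds, gives a number 2.4 percentage points higher from compound 1 to compound 3 (within the scatter), so this position now has three chain lengths behind it rather than two, and no step between them leaves the scatter; with a number 3.4 percentage points lower from compound 1 to compound 2 (within the scatter) set beside these, the small steps do not even share a direction, which means that no trend with chain length can be read from these three compounds. No other measurement on these compounds speaks to why the read-out stays so flat across them.

All three compounds carry long chains and were read at a single concentration, so the result says nothing about how a much shorter chain, such as ethyl, would behave at this place. It also leaves open whether a carboxylic acid or an amine at the end of the chain would give a number beyond the scatter.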